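Ester for amide on the acrylamide series

The compounds below may be only part of what the source reports. "The series", "measured", "known", "first", "only" and "open" are said of these compounds alone.

Among the measured compounds shown here, compound 1 `CNC(=O)/C=C/c1ccncc1-c1ccc2ccccc2c1` is one of two compounds measured in a functional assay on A549 cells (Homo sapiens) for inhibition, read by sulforhodamine B assay, with a stated time of 72 h; a higher number here means a weaker inhibitor of growth, a lower number a stronger inhibitor of growth. Compound 1 gives 6620 nM, the highest of the two numbers shown, while compound 2 `CNC(=O)/C=C/c1ccncc1-c1ccc2c(ccn2C)c1` gives 6450 nM; the two values lie within the scatter of each other, so no order can be read between them. Compound 3 `CCOC(=O)/C=C/c1ccncc1-c1ccc2ccccc2c1` is not yet measured. It differs from compound 1 in one place: ethoxy in place of methylamino on a carbonyl carbon. For the measured compounds named here, no measured pair shows this change, so the step from compound 1 to compound 3 is expected to be small, if anything toward a weaker inhibitor, as a 1.2-fold higher number from compound 1 to compound 3 (0.08 log units; within the scatter). For compound 3 the expected value in this assay is 8000 nM, with a range from 2500 nM to 25000 nM.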

Compound 3, concentration for 50% growth inhibition: 5380 nM
Compound 3: middle estimate off by 1.5-fold (0.17 log units), on the high side, within the range that was stated.
By their numbers in this assay, from the lowest: compounds 3, 2 and 1 (each within the scatter of the next).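

In this assay ethoxy in place of methylamino on a carbonyl carbon gives a 1.2-fold lower number from compound 1 to compound 3 (0.09 log units; within the scatter) and does not separate the two compounds, although one hydrogen-bond donor leaves with the methylamino. This position therefore accepts the ester on the core of compound 1 with no change that can be read. No measurement on hand offers an explanation for this result.

From the compounds shown here alone, whether a carboxylic acid or a longer chain such as butoxy on this carbonyl carbon would give a step beyond the scatter stays open. Going by these compounds, whether the same change behaves alike on the core of compound 2 also stays open.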